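Swapping a Ring for a Basic Chain on a Benzamide

The compounds below may be only part of what the source reports. "The series", "measured", "known", "first", "only" and "open" are said of these compounds alone.

Compound 1 `CCCCCCOc1ccc(C(=O)NC2CCCC2(C)C)cc1` was tested in an assay for activation of potassium voltage-gated channel subfamily KQT member 1 (Cavia porcellus) (a higher number here means a weaker inhibitor, a lower number a stronger inhibitor), and gave only a limit, > 30000 nM, so no number for it is known. A second compound, compound 2 `CCCCc1noc(-c2ccc(C(=O)NC[C@@H]3CCCC3(C)C)cc2)n1`, carries a different core and in this assay compound 2 gives 9 nM. Compound 3 `CCCCCCOc1ccc(C(=O)NCCN(CC)CC)cc1` keeps the core of compound 1 and changes only the group on the amide nitrogen: 2-(diethylamino)ethyl in place of 2,2-dimethylcyclopentyl on an amide-type nitrogen. For the measured compounds named here, no measured pair in this set differs in exactly one place, so the size of such a change has not been seen directly. Because compound 1 sits at the limit of > 30000 nM in this assay, at which 1 of the 2 values shown sits, the starting point for this step is itself only a boundary of the assay, and the expectation for the step from compound 1 to compound 3 is no shift beyond the usual scatter, a number no higher from compound 1 to compound 3 (the limit leaves the size open). Compound 3 is therefore expected to come out near 30000 nM, with a likely range from 8000 nM to 100000 nM, and with a real chance that the assay again reports only a limit for compound 3 rather than a number.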

Compound 3, half-maximal inhibitory concentration: 3500 nM
The estimate for compound 3 lay 8.6-fold (0.93 log units) above the measured number; measured number below the stated range.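

In this assay, the group on the amide-type nitrogen clearly matters on the core of compound 1: 2-(diethylamino)ethyl in place of 2,2-dimethylcyclopentyl gives an at least 8.5-fold lower number from compound 1 to compound 3 (0.93 log units; beyond the scatter). As far as these compounds go, that step starts from a limit and not from a number, so it sets only a minimum, and its true size stays unknown: the limit of > 30000 nM in this assay, at which 1 of the 3 values shown sits. Compound 3 gives 3500 nM, an actual number on this core, which provides a measured reference for judging further changes on this nitrogen.

The swap changes two things at once, removing a ring of carbon only and bringing in an open chain that contains a nitrogen, so this single pair cannot show which of the two accounts for the lower number. A hexyl chain on the same amide-type nitrogen, which has no ring and no nitrogen, would help separate the two, and a 3-(diethylamino)propyl chain would test whether the length of the chain matters as well.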